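The source may report more compounds than this note shows. Statements on the series, on what has been measured and on what is new or still open speak of the compounds shown alone.

Compound 1 `Oc1c(O)c(O)c2c(=S)cc(-c3ccccc3)oc2c1-c1ccc(C(F)(F)F)cc1` was examined in a toxicity assay on Huh-7 cells (Homo sapiens) for cytotoxicity, read by CCK-8 assay, with a stated time of 24 h; on this read-out lower numbers stand for higher toxicity in this test and higher numbers for lower toxicity in this test. In this assay compound 1 gives > 100000 nM, which is a limit of the assay rather than a number. Compound 2 `O=c1cc(-c2ccccc2)oc2c(-c3cc(F)cc(F)c3)c(O)c(O)c(O)c12` likewise reaches only > 100000 nM, again a limit. Compound 3 `O=c1cc(-c2ccc(Nc3ccc(Br)cc3)cc2)oc2cc(O)c(O)c(O)c12` also returns > 100000 nM, a limit as well. Compound 1 therefore stands at the same limit as every other measured compound, since all three values sit there (the limit of > 100000 nM in this assay, at which 3 of the 3 values shown sit). The unmeasured compound 4 `Oc1cc2oc(-c3ccccc3)cc(=S)c2c(O)c1O` differs from compound 1 by hydrogen in place of 4-(trifluoromethyl)phenyl on an aromatic carbon. With every value shown resting at the limit, the expected step is a step that the limit leaves unreadable from compound 1 to compound 4, none beyond the usual scatter. Compound 4 is thus expected to give about 150000 nM in this assay, within a range from 70000 nM to 400000 nM.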

Compound 4, half-maximal cytotoxic concentration: > 100000 nM
Compound 4: no number, only a limit (the forecaster's own chance of this, stated with the estimate: 85%); the middle value does not contradict the limit.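

Compound 1 and compound 4 both rest at a limit in this assay, and no step can be read between them. The compounds shown leave open whether hydrogen in place of 4-(trifluoromethyl)phenyl changes this read-out at all: the limit of > 100000 nM in this assay, at which 4 of the 4 values shown sit.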